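From an ethyl group to a fluoro group on compound 3

This account rests on a few compounds, and the source may have more. Where it says the series, first, only, none or still open, it means among the compounds named here.

Measured so far:
Compound 1, `Nc1ccccc1NC(=O)c1ccc(CSc2cccc(F)c2)cc1`: 3280 nM
Compound 2, `Cc1cc(C)cc(SCc2ccc(C(=O)Nc3ccccc3N)cc2)c1`: 2760 nM
Compound 3, `CCc1ccc(SCc2ccc(C(=O)Nc3ccccc3N)cc2)cc1`: 1750 nM

In a functional assay on SMMC-7721 cells (Homo sapiens) for antiproliferative activity, read by CCK-8 assay, with a stated time of 72 h (a lower number here means a stronger inhibitor, a higher number a weaker inhibitor), compound 3 gives the lowest of the three numbers, yet its steps from compound 2 (a 1.6-fold lower number from compound 2 to compound 3 (0.20 log units; within the scatter)) and from compound 1 (a 1.9-fold lower number from compound 1 to compound 3 (0.27 log units; within the scatter)) both lie within the scatter, so the three cannot be ranked. Compound 4, `Nc1ccccc1NC(=O)c1ccc(CSc2ccc(F)cc2)cc1`, differs from compound 3 by fluoro in place of ethyl on an aromatic carbon. The step that bears on this is a 1.9-fold lower number from compound 1 to compound 3 (0.27 log units; within the scatter), which exchanged 3-fluorophenyl for 4-ethylphenyl and stayed within the scatter. Returning to a fluoro group is therefore expected to move the number little, perhaps slightly upward. The expected step is a 1.5-fold higher number from compound 3 to compound 4 (0.17 log units; within the scatter), giving compound 4 an estimated 2600 nM, with a range from 1300 nM to 5200 nM.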

Compound 4, half-maximal inhibitory concentration: 5770 nM
Compound 4: the middle estimate sits 2.2-fold (0.35 log units) below what was measured; the whole stated range lies below it.
By their numbers in this assay, from the lowest: compounds 3, 2, 1 and 4 (each within the scatter of the next, the first and the last beyond it).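

In this assay, among the compounds shown here, the change from ethyl to fluoro gives a 3.3-fold higher number from compound 3 to compound 4 (0.52 log units; beyond the scatter) and, unlike the earlier steps, clears the scatter, so the group at this position can change the number. The same holds for a 2.1-fold higher number from compound 2 to compound 4 (0.32 log units; beyond the scatter) but not for a 1.8-fold higher number from compound 1 to compound 4 (0.25 log units; within the scatter) and so the 3-fluorophenyl and 4-fluorophenyl groups cannot be told apart. No measurement shown here explains the change. On these data alone, whether a longer chain such as propyl would lower the number further remains open. So does whether a methoxy group or an amine on the same carbon would behave like ethyl or like fluoro.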